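Changing the amide cap on a shared chromone-acid core

A few compounds are considered here, and "the series" means these few. Any claim that something is new, unique, unknown or untested is made for them only; others in the source may bear on it.

Measured compounds:
Compound 1, `O=C(Nc1cc(F)cc2c(=O)cc(C(=O)O)oc12)c1ccc(Cl)c(Cl)c1`: in an assay on CHO cells for agonist activity at G protein-coupled receptor GPR35 (Rattus norvegicus), read by a beta-galactosidase reporter and beta-arrestin recruitment, with a stated time of 90 min (a higher number here means that more compound is needed for the effect, a lower number that less compound is needed), compound 1 gives 2650 nM.
Compound 2, `Cc1cccc(C(=O)Nc2cc(Cl)cc3c(=O)cc(C(=O)O)oc23)c1`: in this assay compound 2 gives 2100 nM.
Compound 3, `Cc1cccc(C(=O)Nc2cccc3c(=O)cc(C(=O)O)oc23)c1`: in this assay compound 3 gives 2750 nM.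

All three values sit within the usual scatter of one another, so compound 2 cannot be set apart from compound 1 or compound 3 on these numbers. For the measured compounds named here, the one measured step that changes a single place, a 1.3-fold higher number from compound 2 to compound 3 (0.12 log units; within the scatter), removes the chloro from the shared core and leaves the number where it was. Compound 1 and compound 2 differ in two places, so their two values can only be compared directly, and they agree within the scatter.

Compound 4, `COc1ccc(C(=O)Nc2cc(Cl)cc3c(=O)cc(C(=O)O)oc23)cc1`, differs from compound 2 by 4-methoxyphenyl in place of 3-methylphenyl on a carbonyl carbon. Going by the values given here, no measured step touches this amide aryl group, so nothing here speaks directly for a change in either direction. Given how little the other variations moved the number, the step from compound 2 to compound 4 is expected to stay within the scatter, a 1.2-fold higher number from compound 2 to compound 4 (0.08 log units; within the scatter). Compound 4 is therefore estimated to give about 2500 nM in this assay, most likely between 900 nM and 7000 nM.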

Compound 4, half-maximal effective concentration: 1830 nM
For compound 4 the middle estimate is 1.4-fold (0.14 log units) above the measured one; the range from low to high includes it.
By their numbers in this assay, from the lowest: compounds 4, 2, 1 and 3 (each within the scatter of the next).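

For the compounds shown here, compound 4 supplies the first measured step at the amide aryl group, on the carbonyl carbon whose other neighbour is the amide-type nitrogen: in this assay, 4-methoxyphenyl in place of 3-methylphenyl gives a 1.1-fold lower number from compound 2 to compound 4 (0.06 log units; within the scatter). This step stays within the scatter even though the entering group adds an oxygen and a hydrogen-bond acceptor, so for this pair the swap leaves the number unchanged, as removing the chloro from the shared core did in a 1.3-fold higher number from compound 2 to compound 3 (0.12 log units; within the scatter). Nothing available here accounts for this flat result.

One pair cannot separate the two differences between these groups, the change from methyl to methoxy and the different numbering of the group on the ring, so neither has been tested alone. Also open, as far as these compounds go, is whether a more different group at this position, such as an aminophenyl or carboxyphenyl ring, or a longer alkyl chain in place of the aromatic ring, would move the number beyond the scatter in either direction.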